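Adding bromo to the most active compound

A few compounds are considered here, and "the series" means these few. Any claim that something is new, unique, unknown or untested is made for them only; others in the source may bear on it.

Measured in a functional assay on HCT-116 cells (Homo sapiens) for antiproliferative activity, read by MTT assay, with a stated time of 48 h; a higher number here means a weaker inhibitor, a lower number a stronger inhibitor:
- compound 1 `CCCCCCC(CCO)n1c(Br)nc2c(Cl)ncnc21`: 16100 nM
- compound 2 `CCCCCCCC(CCO)n1c(Br)nc2c(Cl)ncnc21`: 16200 nM
- compound 3 `CCCCCCCCC(CCO)n1cnc2c(Cl)ncnc21`: 1650 nM

Compound 3 has the lowest number of the three, which makes it the strongest inhibitor so far, and compound 1 and compound 2 both sit well above it.

Compound 4 `CCCCCCCCC(CCO)n1c(Br)nc2c(Cl)ncnc21` keeps the chain of compound 3 and carries bromo in place of hydrogen on an aromatic carbon, between two ring nitrogen atoms: bromo in place of hydrogen on an aromatic carbon. Compound 1 and compound 2 carry bromo there too.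

Going by the values given here, no measured step isolates this swap. Among the compounds with values here, the only measured step, a 1.0-fold higher number from compound 1 to compound 2 (0.00 log units; within the scatter), lengthens the chain of a bromo compound and stays within the scatter. The closest measured relative of compound 4 is compound 2, which gives 16200 nM. Going by these compounds, compound 3 also differs from it in chain length, so the chain's share of the gap remains unknown. Compound 4 is therefore expected to lie nearer compound 2 than compound 3, perhaps a little below compound 2, giving a clear rise in the number and a weaker inhibitor.

The expected change is a 6.7-fold higher number from compound 3 to compound 4 (0.82 log units; beyond the scatter).

For compound 4 the estimate is 11000 nM, with an expected range of 4000 nM to 25000 nM.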

Compound 4, half-maximal inhibitory concentration: 22400 nM
Compound 4: middle estimate off by 2.0-fold (0.31 log units), on the low side, and the stated range covers the measured number.
By their numbers in this assay, from the lowest: compound 3; then compounds 1, 2 and 4 (each within the scatter of the next).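

In this assay, the swap of hydrogen for bromo on the aromatic carbon between two ring nitrogen atoms can now be read on a single chain, and it gives a 14-fold higher number from compound 3 to compound 4 (1.13 log units; beyond the scatter) as a large step towards weaker inhibition. Once bromo is present, the chain adds little to the picture: a 1.4-fold higher number from compound 2 to compound 4 (0.14 log units; within the scatter) and a 1.4-fold higher number from compound 1 to compound 4 (0.14 log units; within the scatter) both lie within the scatter, as does the earlier 1.0-fold higher number from compound 1 to compound 2 (0.00 log units; within the scatter), so these three bromo compounds cannot be told apart by chain length. Nothing on hand explains why this single change has so large an effect.

Compound 3 is the only compound here without bromo, so the compounds shown leave open whether chain length matters when that aromatic carbon carries hydrogen, where differences hidden by the bromo compounds might appear. They also leave open whether the rise in the number belongs to bromo itself or would also follow from another group at this carbon, such as an amine or a methoxy group.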